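The compounds below may be only part of what the source reports. "The series", "measured", "known", "first", "only" and "open" are said of these compounds alone.

Compound 3 `COC(=O)/C=C/[C@H]1C[C@@H](O)[C@@H](O)C1` is one of three compounds tested in an ADME assay on S2 cells (Drosophila melanogaster) for cytotoxicity, read by MTT assay; a higher number here means that more compound is needed for the effect, a lower number that less compound is needed. In this assay compound 3 reaches only a limit, > 350000 nM. Compound 2 `CCOC(=O)/C=C/[C@H]1C[C@@H](O)[C@@H](O)C1` likewise reaches only a limit in this assay, > 350000 nM. Compound 1 `CCCCCC[C@H]1C[C@@H](O)[C@@H](O)C1` gives a number in this assay, 110000 nM. Among the compounds with values here, the single one-place step among the measured compounds, a step that the two limits leave unreadable from compound 2 to compound 3, cannot be sized because the limit of > 350000 nM in this assay, at which 2 of the 3 values shown sit, covers both of its ends. Compound 4 `CCCCCCOC(=O)/C=C/[C@H]1C[C@@H](O)[C@@H](O)C1` differs from compound 3 by pentyl in place of hydrogen on a saturated chain carbon bound to an oxygen next to a carbonyl group. With no readable step to lean on, the value of compound 4 in this assay is expected near 200000 nM, within 70000 nM to 350000 nM, and the step from compound 3 is estimated as an at least 1.7-fold lower number from compound 3 to compound 4 (0.24 log units; that floor lies within the scatter).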

Compound 4, half-maximal effective concentration: > 350000 nM
Compound 4: only a limit was reported (the forecaster's own chance of this, stated with the estimate: 45%); at least 1.7-fold (0.24 log units) between middle value and limit.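

Compound 4 yields no readable step to compound 2 or compound 3, because all three stop at a limit: the limit of > 350000 nM in this assay, at which 3 of the 4 values shown sit. The compounds shown leave open whether pentyl in place of hydrogen changes the result in this assay at all.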